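This account rests on a few compounds, and the source may have more. Where it says the series, first, only, none or still open, it means among the compounds named here.

Working notes on the series. Of the compounds shown here, two have numbers so far. Compound 2 `N=C(NCCCc1c[nH]cn1)NCCC(c1ccc(Cl)cc1)c1ccccn1` gives 7.84 in a functional assay on cardiac atrium for agonist activity at histamine H2 receptor (Cavia porcellus) (a lower number here means a less potent compound, a higher number a more potent compound, by a factor of ten per unit of this negative logarithm), the higher of the two values; compound 1 `COc1ccc(C(CC/N=C(\N)NCCCc2c[nH]cn2)c2ccccn2)cc1` gives 7.44 in this assay, a gap that lies beyond the usual scatter of repeated measurements. Within the data shown here, no pair of measured compounds differs in only one place, so no single step has yet been isolated.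

Compound 3 `N=C(NCCCc1c[nH]cn1)NCCC(c1ccc(Cl)c(Cl)c1)c1ccccn1` is the next one to be measured. It differs from compound 2 in one place: chloro in place of hydrogen on an aromatic carbon. Nothing among the two measured compounds shows what this change does in this assay; the comparison between compound 1 and compound 2 involves a different substituent and a different position and cannot be read across. For compound 3 a step of a number 0.11 log units higher from compound 2 to compound 3 (within the scatter) relative to compound 2 is expected, which is within the scatter, so no clear direction is claimed. The estimate for compound 3 in this assay is 7.95, with a range from 7.45 to 8.45.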

Compound 3, negative logarithm of the half-maximal effective concentration: 8.19
Compound 3: the middle estimate sits 0.24 log units below what was measured; low and high end bracket the measured number.
By their numbers in this assay, from the lowest: compound 1; then compound 2; then compound 3.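

In this assay, among these compounds, the change from 4-chlorophenyl to 3,4-dichlorophenyl gives a number 0.35 log units higher from compound 2 to compound 3 (beyond the scatter) and is the first single step isolated. Chloro in place of hydrogen on this aromatic carbon, ortho to a chloro group, therefore raises agonist potency modestly, which the comparison of compound 1 and compound 2 could not show. No measurement at hand accounts for the rise.

Going by these compounds, whether a fluoro, methyl or trifluoromethyl group on this carbon would give a step of similar size remains open. On these data alone, it is also open whether the same step would appear without the existing chloro group, since this change has been read only on the 4-chlorophenyl compound.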